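Pentyl to propyl on the shared core: compound 1 to compound 3

The source may hold more compounds than are shown below. What is called first, only, known or untested is meant among the compounds shown, and "the series" means these compounds.

Measured in an ADME assay on HeLa cells (Homo sapiens) for inhibition, read by MTT assay; on this read-out higher numbers stand for weaker inhibition of growth and lower numbers for stronger inhibition of growth: compound 1 `CCCCCc1cc2c(=O)n(CCCSc3nc(-c4cc(OC)c(OC)c(OC)c4)c(C#N)c(=O)[nH]3)cnc2s1` gives 75.8 ug/mL; compound 2 `N#Cc1c(-c2ccc(O)cc2)[nH]c(=S)[nH]c1=O` gives 90.8 ug/mL.

Compound 1 and compound 2 sit within the scatter of each other, so neither stands apart on what has been measured. Compound 3 `CCCc1cc2c(=O)n(CCCSc3nc(-c4cc(OC)c(OC)c(OC)c4)c(C#N)c(=O)[nH]3)cnc2s1` keeps the core of compound 1 and differs by hydrogen in place of ethyl on a saturated chain carbon, three bonds along the chain from an aromatic carbon. Going by the values given here, no pair of measured compounds bears on this change, so nothing measured tells how chain length acts in this assay; the step expected is none beyond the scatter, leaning if anything toward a higher number. Compound 3 is therefore expected at 85 ug/mL, within 45 ug/mL to 160 ug/mL, the step being a 1.1-fold higher number from compound 1 to compound 3 (0.05 log units; within the scatter).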

Compound 3, concentration for 50% growth inhibition: 52.5 ug/mL
Compound 3: the middle estimate sits 1.6-fold (0.21 log units) above what was measured; the range from low to high includes it.
By their numbers in this assay, from the lowest: compounds 3, 1 and 2 (each within the scatter of the next).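

Pentyl to propyl on the shared core gives a 1.4-fold lower number from compound 1 to compound 3 (0.16 log units; within the scatter) in this assay. Going by these compounds alone, this is the first pair bearing on chain length at this position, and it shows that hydrogen in place of ethyl on this saturated chain carbon leaves the number within the scatter. Nothing measured accounts for this step.

Still open, going by these compounds, is whether a longer chain such as heptyl, or a shorter one such as methyl, would move the number beyond the scatter. On these data alone, a chain carrying an amine or a carboxylic acid also remains open.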